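From Propyl to Ethyl on Compound 1

The compounds below may be only part of what the source reports. "The series", "measured", "known", "first", "only" and "open" are said of these compounds alone.

In a functional assay on HeLa cells (Homo sapiens) for inhibition, read by sulforhodamine B assay (on this read-out higher numbers stand for weaker inhibition and lower numbers for stronger inhibition), compound 1 (`CCCc1ccc(NC2=CC(=O)c3nc4n(c3C2=O)[C@H]2OC[C@@H](O)[C@H]2OC4)cc1`) gives 4990 nM as its reading. Among the compounds with values here, the only other measured compound, compound 2 (`Cc1ccc(NC2=CC(=O)c3c(nc4n3[C@H]3OC[C@@H](O)[C@H]3OC4)C2=O)cc1C`), gives 4320 nM in the same test. These two numbers lie within the scatter of each other, so compound 1 stands level with compound 2. Neither number says anything yet about changes to the chain.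

Compound 3 (`CCc1ccc(NC2=CC(=O)c3nc4n(c3C2=O)[C@H]2OC[C@@H](O)[C@H]2OC4)cc1`) differs from compound 1 in one place: hydrogen in place of methyl on a saturated chain carbon, two bonds along the chain from an aromatic carbon. This turns 4-propylphenyl into 4-ethylphenyl.

Within the data shown here, no measured pair shows a change of this kind, so any forecast is weakly founded. In this assay no step beyond the scatter is expected, and no direction is favoured. Compound 3 is expected at 4500 nM in this test, with an estimated range of 2300 nM to 8500 nM for its reading. The estimate amounts to a 1.1-fold lower number from compound 1 to compound 3 (0.04 log units; within the scatter) as the expected step, which would stay within the scatter.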

Compound 3, half-maximal inhibitory concentration: 3990 nM
Beside the measured number, compound 3's estimate is 1.1-fold (0.05 log units) above it; measured number inside the range.
By their numbers in this assay, from the lowest: compounds 3, 2 and 1 (each within the scatter of the next).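

In this assay, within the data shown here, the one step available for this position is a 1.3-fold lower number from compound 1 to compound 3 (0.10 log units; within the scatter) and it shows that 4-propylphenyl and 4-ethylphenyl cannot be told apart on this read-out. The earlier compounds shown here offered no pair of this kind, so only now can it be said that, on the core of compound 1, the reading stays level when hydrogen takes the place of methyl on a saturated chain carbon, two bonds along the chain from an aromatic carbon. No measurement at hand offers an explanation for this result.

Going by these compounds, whether a shorter methyl group, a longer butyl chain, or an amine or a carboxylic acid at the end of the chain would leave the reading level or move it beyond the scatter stays open. A single step within the scatter sets no trend along the chain, and it speaks only for this one pair of compounds on the shared core and for this one test on HeLa cells.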